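A few compounds are considered here, and "the series" means these few. Any claim that something is new, unique, unknown or untested is made for them only; others in the source may bear on it.

Among the measured compounds shown here, compound 1 `C=C1C(=O)[C@]23C[C@@]1(O)CC[C@H]2c1ccc(O)c(C)c1[C@@H]3Cn1cc(-c2ccc(C(F)(F)F)cc2)nn1` is the one member of this set with a number in a functional assay on MCF7 cells (Homo sapiens) for cytotoxicity, read by MTT assay, with a stated time of 4 days; a lower number here means a stronger inhibitor, a higher number a weaker inhibitor: compound 1 gives 1840 nM. Compound 2 `Cc1ccc(S(=O)(=O)Oc2ccc3c(c2C)[C@H](Cn2cc(-c4ccc(C(F)(F)F)cc4)nn2)[C@@]24CC(=O)[C@@](C)(CC[C@@H]32)C4)cc1` reaches only the limit of the assay in this assay, recorded for compound 2 as > 20000 nM. Compound 3 `Cc1c(O)ccc2c1[C@H](Cn1cc(-c3ccc(Cl)cc3)nn1)[C@@]13CC(=O)[C@@](C)(CC[C@@H]21)C3` likewise meets the limit, recorded for compound 3 as > 20000 nM. For the measured compounds named here, two of the three values thus rest at the limit of > 20000 nM in this assay, at which 2 of the 3 values shown sit, and neither compound differs from compound 1 in a single place, so no measured step exists. Compound 4 `C=C1C(=O)[C@]23C[C@@]1(O)CC[C@H]2c1ccc(O)c(C)c1[C@@H]3Cn1cc(-c2ccc(OC)cc2)nn1` is not yet measured and differs from compound 1 by methoxy in place of trifluoromethyl on an aromatic carbon. Going by the values given here, no measured pair shows what this change does. The expected step is small, a 1.6-fold higher number from compound 1 to compound 4 (0.21 log units; within the scatter), none beyond the scatter in either direction. Compound 4 is therefore estimated at 3000 nM, within 900 nM to 10000 nM.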

Compound 4, half-maximal inhibitory concentration: 1710 nM
Estimate against measurement, compound 4: 1.8-fold (0.24 log units) above; measured number inside the range.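

Replacing trifluoromethyl with methoxy on an aromatic carbon para to a large group gives, in this assay, a 1.1-fold lower number from compound 1 to compound 4 (0.03 log units; within the scatter). At this position, then, two different groups give values that cannot be told apart on the core of compound 1. Nothing shown accounts for this lack of a readable change.

Going by these compounds, whether an amine, a carboxylic acid or a longer chain at this position would move the number beyond the scatter remains open. So does whether any other position on this ring responds more strongly.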